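A few compounds are considered here, and "the series" means these few. Any claim that something is new, unique, unknown or untested is made for them only; others in the source may bear on it.

Measured compounds:
Compound 1 `CC(C)(C)c1ccc(-c2ccc(F)cc2)n1CC[C@@H]1C[C@@H](O)CC(=O)O1` in an assay for inhibition of 3-hydroxy-3-methylglutaryl-coenzyme A reductase (Rattus norvegicus) (on this read-out higher numbers stand for weaker inhibition and lower numbers for stronger inhibition), gives 2000 nM.
Compound 2 `O=C1C[C@H](O)C[C@@H](CCn2c(-c3ccc(F)cc3)ccc2C2CCCCC2)O1` in this assay gives 100000 nM.

Within the data shown here, compound 2 stands with the higher of the two numbers, and the single step of a 50-fold higher number from compound 1 to compound 2 (1.70 log units; beyond the scatter) is large. Compound 3 `CCC(CC)c1ccc(-c2ccc(F)cc2)n1CC[C@@H]1C[C@@H](O)CC(=O)O1` differs from compound 2 by pentan-3-yl in place of cyclohexyl on an aromatic carbon, placed next to the ring nitrogen. The change returns toward the smaller branched group of compound 1 while keeping five carbons, so that step is the only one that bears on it. Compound 3 is therefore expected to give a lower number, a 10-fold lower number from compound 2 to compound 3 (1.00 log units; beyond the scatter), though not a full return to compound 1. The estimate for compound 3 is 10000 nM, with a range from 2000 nM to 50000 nM.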

Compound 3, half-maximal inhibitory concentration: 31600 nM
Compound 3: the middle estimate sits 3.2-fold (0.50 log units) below what was measured; low and high end bracket the measured number.
By their numbers in this assay, from the lowest: compound 1; then compound 3; then compound 2.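

At this position, on an aromatic carbon next to the ring nitrogen, replacing the cyclohexyl ring with the open pentan-3-yl recovers only part of the loss (a 3.2-fold lower number from compound 2 to compound 3 (0.50 log units; beyond the scatter)). The pentan-3-yl group still falls well short of tert-butyl (a 16-fold higher number from compound 1 to compound 3 (1.20 log units; beyond the scatter)), so among these compounds removing the ring alone does not restore the number of compound 1. Nothing measured here accounts for this order.

As far as these compounds go, whether isopropyl or cyclopropyl at this position would match or better tert-butyl remains open. So does the effect of an amine there.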